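This account rests on a few compounds, and the source may have more. Where it says the series, first, only, none or still open, it means among the compounds named here.

Measured so far in an ADME assay on PC-3 cells (Homo sapiens) for cytotoxicity, read by WST assay, tested at 100 uM; on this read-out lower numbers stand for less inhibition and higher numbers for more inhibition at the one concentration tested (going by the name of the read-out):
compound 1, `CS(=O)(=O)Nc1cccc(C(=O)N2CCCC(C(=O)Nc3ccc(Cl)cc3)C2)c1`, gives 3%;
compound 2, `CS(=O)(=O)c1cccc(C(=O)N2CCCC(C(=O)Nc3ccc(Cl)cc3)C2)c1`, gives 2%.

Compound 2 stands lowest of the two numbers, yet its nearest neighbour, compound 1, lies within the usual scatter of it: the step of a number 1 percentage points lower from compound 1 to compound 2 (within the scatter) is too small to count as a change, so the two compounds are to be read as equal on this read-out. Both sit at the bottom of the scale, far from any marked inhibition.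

Compound 3, `CSc1cccc(C(=O)N2CCCC(C(=O)Nc3ccc(Cl)cc3)C2)c1`, has not yet been measured in this assay. It differs from compound 2 in one place, (methylsulfanyl in place of methylsulfonyl on an aromatic carbon). For the measured compounds named here, the only step on record, from compound 1 to compound 2, also sits on the same aromatic carbon and was within the scatter, which is all the guidance the data give. With both measured compounds near the floor of the read-out and no step beyond the scatter anywhere, compound 3 is expected to stay close to compound 2, with a step of a number 3 percentage points higher from compound 2 to compound 3 (within the scatter) that should not exceed the scatter. The estimate for compound 3 in this assay is therefore 5%, with a range from 0% to 20%.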

Compound 3, a percentage reported as inhibition, at one concentration (the size of the read-out at that concentration, not a potency): 0%
Compound 3: middle estimate off by 5 percentage points, on the high side, and the stated range covers the measured number.
By their numbers in this assay, from the lowest: compounds 3, 2 and 1 (each within the scatter of the next).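

On the aromatic carbon meta to a large group, methylsulfanyl now joins methylsulfonyl and methanesulfonamido, and in this assay the exchange for methylsulfonyl gives a number 2 percentage points lower from compound 2 to compound 3 (within the scatter) and the exchange for methanesulfonamido gives a number 3 percentage points lower from compound 1 to compound 3 (within the scatter) on the same core. With a group of fewer heavy atoms and no double bonds outside aromatic rings at this position, the number stays level within the scatter, so all three compounds read as equal and stay at the bottom of the scale. No measured evidence bears on why this exchange leaves the read-out unmoved.

The compounds shown leave open whether an amine or a carboxylic acid on this aromatic carbon, or a longer chain in place of the methyl of methylsulfanyl, would lift the read-out away from the bottom of the scale. They also leave open whether replacing the chlorine on the other aromatic ring would do so, since every change shown here falls at this one position.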